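A few compounds are considered here, and "the series" means these few. Any claim that something is new, unique, unknown or untested is made for them only; others in the source may bear on it.

Measured in a functional assay on HT-29 cells (Homo sapiens) for cytotoxicity, read by MTT assay, with a stated time of 6 days; on this read-out higher numbers stand for an effect only at larger amounts of compound and lower numbers for an effect already at smaller amounts:
Compound 1 (`COC(=O)c1c(-c2ccc(OC)cc2)oc2ccccc2c1=O`): > 25 ug/mL (a limit, not a number)
Compound 2 (`O=c1cc(-c2ccc([N+](=O)[O-])cc2)oc2cc(O)ccc12`): 6.95 ug/mL

Going by the values given here, only two compounds have been tested in this assay, and compound 2 holds the only true number, 6.95 ug/mL. Compound 1 is reported only as a limit of the assay, > 25 ug/mL. Compound 2 therefore has no measured neighbour to be ranked against, and its number is the sole anchor for what follows.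

Compound 3 (`O=c1cc(-c2ccc([N+](=O)[O-])cc2)oc2c(O)c(O)ccc12`) has not yet been measured. It differs from compound 2 by a single change: hydroxy in place of hydrogen on an aromatic carbon. In words, a hydroxy group takes the place of hydrogen on an aromatic carbon, ortho to the hydroxy group already present.

Among the compounds with values here, no measured pair shows what this change does, so the expectation is a cautious one. It starts from compound 2 at 6.95 ug/mL and assumes no large shift in this assay. The estimated 1.3-fold lower number from compound 2 to compound 3 (0.10 log units; within the scatter) is small, leaning slightly toward lower numbers and expected to stay within the usual scatter. Compound 3 is expected at 5.5 ug/mL, with an estimated range from 1.8 ug/mL to 17 ug/mL.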

Compound 3, concentration for half-maximal effect: 3.46 ug/mL
Beside the measured number, compound 3's estimate is 1.6-fold (0.20 log units) above it, within the range that was stated.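

Going by these compounds alone, the replacement of hydrogen by hydroxy on an aromatic carbon, ortho to a fused ring and ortho to a hydroxy group, gives the first step that can be read in this assay (a 2.0-fold lower number from compound 2 to compound 3 (0.30 log units; within the scatter)). This position therefore carries a second hydroxy group with no shift that stands clear of the usual scatter, so compound 2 and compound 3 cannot be put in order on this read-out. Nothing at hand bears on why the step is this size.

Going by these compounds, it remains open whether an amine, a carboxylic acid or a fluorine atom on this same aromatic carbon would also stay within the scatter, and whether a hydroxy group here would do so without the hydroxy group already present. Within the data shown here, the single step also leaves open whether this result holds on cores other than the one shared by compound 2 and compound 3.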